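From Iodophenyl to Carboxycyclohexyl in a Cytotoxic Series

This account rests on a few compounds, and the source may have more. Where it says the series, first, only, none or still open, it means among the compounds named here.

Three compounds built on one shared core have numbers in a functional assay on A549 cells (Homo sapiens) for cytotoxicity, read by MTT assay; a lower number here means a stronger inhibitor, a higher number a weaker inhibitor. Compound 1 `Oc1ccc(CN(Cc2ccccc2C(F)(F)F)Cc2ccc(O)c3ncccc23)c2cccnc12` gives 46 nM, and compound 2 `Oc1ccc(CN(Cc2cccc(C(F)(F)F)c2)Cc2ccc(O)c3ncccc23)c2cccnc12` gives 38 nM. These two are separated by a 1.2-fold lower number from compound 1 to compound 2 (0.08 log units; within the scatter). Compound 3 `Oc1ccc(CN(Cc2cccc(I)c2)Cc2ccc(O)c3ncccc23)c2cccnc12` gives 350 nM, the highest number of the three, which makes it the weakest inhibitor measured so far.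

Compound 4 `O=C(O)C1CCC(CN(Cc2ccc(O)c3ncccc23)Cc2ccc(O)c3ncccc23)CC1` has not yet been measured. It carries 4-carboxycyclohexyl in place of 3-iodophenyl on a saturated chain carbon bound to an amine nitrogen.

Within the data shown here, the steps that bear on this change are those altering the same group, namely a 7.6-fold higher number from compound 1 to compound 3 (0.88 log units; beyond the scatter) and a 9.2-fold higher number from compound 2 to compound 3 (0.96 log units; beyond the scatter). Both are modest, and both only exchange one substituted phenyl for another. Among the measured compounds shown here, no measured compound has a non-aromatic ring at this place, so the data give only weak guidance. A step of similar or smaller size is expected, towards a higher number in this assay, though a step in the other direction cannot be excluded. Compound 4 is expected at about 900 nM, with an estimated range of 200 nM to 4000 nM. This expectation amounts to a 2.6-fold higher number from compound 3 to compound 4 (0.41 log units; beyond the scatter).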

Compound 4, half-maximal inhibitory concentration: 661 nM
For compound 4 the middle estimate is 1.4-fold (0.13 log units) above the measured one; low and high end bracket the measured number.
By their numbers in this assay, from the lowest: compounds 2 and 1 (each within the scatter of the next); then compounds 3 and 4 (each within the scatter of the next).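

Among these compounds, compound 4 puts a non-aromatic ring on a saturated chain carbon bound to an amine nitrogen, where the earlier compounds carried only substituted phenyl groups. In this assay the exchange of 3-iodophenyl for 4-carboxycyclohexyl gives a 1.9-fold higher number from compound 3 to compound 4 (0.28 log units; within the scatter), so among these compounds an aromatic ring at this place is not required for a value in the range of compound 3, and the 4-carboxycyclohexyl and 3-iodophenyl groups cannot be told apart here. Set against the two trifluoromethyl compounds, the same group gives a 17-fold higher number from compound 2 to compound 4 (1.24 log units; beyond the scatter) and a 14-fold higher number from compound 1 to compound 4 (1.16 log units; beyond the scatter), both large steps, which leaves 2-(trifluoromethyl)phenyl and 3-(trifluoromethyl)phenyl as the only groups shown here with the lower numbers.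

Nothing available explains these differences. On these data alone, whether the result follows from the cyclohexyl ring or from the carboxylic acid stays open, and a plain cyclohexyl or a 4-carboxyphenyl group would help to separate the two; how an amine or an ester in place of the carboxylic acid, or a longer chain carrying it, would compare also remains open.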